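Thiophene for furan on the amide carbonyl of compound 3

The compounds below may be only part of what the source reports. "The series", "measured", "known", "first", "only" and "open" are said of these compounds alone.

Compound 3 `CC(C)=CCC/C(C)=C/CC1Cc2c(OCCCNC(=O)c3ccco3)cc(=O)n(CCCO)c2CC1(C)C` stands highest of the three measured numbers: in a functional assay on PANC-1 cells (Homo sapiens) for inhibition, read by MTT assay, with a stated time of 24 h, tested at 10 uM (on this read-out higher numbers stand for more inhibition at the one concentration tested (going by the name of the read-out) and lower numbers for less inhibition), compound 3 gives 69.5%, while compound 2 `COc1ccc(C(=O)NCCCOc2cc(=O)n(CCCO)c3c2CC(C/C=C(\C)CCC=C(C)C)C(C)(C)C3)cc1` gives 45.7% and compound 1 `CC(C)=CCC/C(C)=C/CC1Cc2c(OCCCNS(=O)(=O)c3ccc(Cl)cc3)cc(=O)n(CCCO)c2CC1(C)C` gives 14.5%, both gaps beyond the scatter. Compound 4 `CC(C)=CCC/C(C)=C/CC1Cc2c(OCCCNC(=O)c3cccs3)cc(=O)n(CCCO)c2CC1(C)C` differs from compound 3 only at the carbonyl carbon: thiophen-2-yl in place of furan-2-yl on a carbonyl carbon. Among the compounds with values here, the one measured step on that carbonyl carbon is a number 23.8 percentage points higher from compound 2 to compound 3 (beyond the scatter), a modest gain, though the groups exchanged there are unlike the present pair. The steps of a number 31.2 percentage points higher from compound 1 to compound 2 (beyond the scatter) and a number 55 percentage points higher from compound 1 to compound 3 (beyond the scatter) concern the sulfonyl-to-carbonyl exchange and do not bear directly. Within the data shown here, no step speaks to furan-2-yl against thiophen-2-yl, so for compound 4 a step within the scatter is expected, a number 6.5 percentage points lower from compound 3 to compound 4 (within the scatter). Compound 4 is therefore estimated near 63%, within 46% to 78%.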

Compound 4, a percentage reported as inhibition, at one concentration (the size of the read-out at that concentration, not a potency): 72.8%
The estimate for compound 4 lay 9.8 percentage points below the measured number, and the stated range covers the measured number.
By their numbers in this assay, from the lowest: compound 1; then compound 2; then compounds 3 and 4 (each within the scatter of the next).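

In this assay, the two five-membered aromatic rings on the carbonyl carbon read alike (a number 3.3 percentage points higher from compound 3 to compound 4 (within the scatter)), so this position accepts sulfur for oxygen in the ring without a step beyond the scatter. The thiophen-2-yl ring also keeps the margin over the other two groups, with a number 27.1 percentage points higher from compound 2 to compound 4 (beyond the scatter) against 4-methoxyphenyl and a number 58.3 percentage points higher from compound 1 to compound 4 (beyond the scatter) against the (4-chlorophenyl)sulfonyl group on the amine nitrogen. Nothing measured accounts for these steps.

Open, on these data alone, is whether a saturated tetrahydrofuran-2-yl ring or a pyrrol-2-yl ring on the same carbonyl carbon would hold this level.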